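The source may hold more compounds than are shown below. What is called first, only, known or untested is meant among the compounds shown, and "the series" means these compounds.

Measured compounds:
compound 1 `CCOC(=O)c1cnn(-c2nc(-c3ccc(OC)cc3)c(C#N)c(=O)n2C)c1N` — 74 ug/mL
compound 2 `CN(C)c1ccc(-c2nc(NN)n(C)c(=O)c2C#N)cc1` — 66 ug/mL
compound 3 `CSc1nc(-c2ccccc2O)c(C#N)c(=O)n1C` — 39 ug/mL

In a functional assay, with a stated time of 10 min (on this read-out higher numbers stand for weaker inhibition and lower numbers for stronger inhibition), compound 1 gives 74 ug/mL, the highest of the three numbers. Compound 2 gives 66 ug/mL and compound 3 gives 39 ug/mL; both gaps from compound 1 lie within the usual scatter of repeated measurements, so the three compounds cannot be separated on this read-out. Among the measured compounds shown here, no pair of measured compounds differs in only one place, so there is no measured step to anchor the change toward compound 4.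

Compound 4 `CCOC(=O)c1cnn(-c2nc(-c3cccc(O)c3O)c(C#N)c(=O)n2C)c1N` is not yet measured. It differs from compound 1 in one place: 2,3-dihydroxyphenyl in place of 4-methoxyphenyl on an aromatic carbon. For the measured compounds named here, nothing among the measured compounds isolates the effect of this change. As the three measured values sit within the scatter of one another, the expected step is a 1.3-fold lower number from compound 1 to compound 4 (0.13 log units; within the scatter), small and with no direction beyond the scatter. For compound 4 the value in this assay is estimated at 55 ug/mL, with a range from 25 ug/mL to 120 ug/mL.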

Compound 4, half-maximal inhibitory concentration: 53 ug/mL
Estimate against measurement, compound 4: 1.0-fold (0.02 log units) above, and the stated range covers the measured number.
By their numbers in this assay, from the lowest: compounds 3, 4, 2 and 1 (each within the scatter of the next).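

In this assay, among the compounds shown here, the first pair that differs in one place gives a 1.4-fold lower number from compound 1 to compound 4 (0.14 log units; within the scatter), for 2,3-dihydroxyphenyl in place of 4-methoxyphenyl on the aromatic carbon ortho to a cyano group. At this position, then, two aryl groups with different hydrogen-bond donor and acceptor counts cannot be separated on this read-out, which is a direct comparison that compounds 1 to 3 alone could not offer. No measurement at hand accounts for this result.

Still open, from the compounds shown here alone, is whether either hydroxyl of the 2,3-dihydroxyphenyl group counts on its own, and whether an unsubstituted phenyl, or a phenyl carrying a carboxylic acid or an amine, would move the number beyond the scatter. Also open, going by these compounds, is whether the same exchange would read alike with the other groups of the core changed.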